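Shortening the Side Chain of a Cyclic Nucleotide Analogue

The source may hold more compounds than are shown below. What is called first, only, known or untested is meant among the compounds shown, and "the series" means these compounds.

Measured so far:
- compound 1, `CCCCCCCCc1cn([C@H]2C[C@H](O)[C@@H](CO)O2)c(=O)[nH]c1=O`, gives 52 ug/mL in a functional assay on Raji cells (Homo sapiens); a higher number here means a weaker inhibitor, a lower number a stronger inhibitor
- compound 2, `CCc1cn([C@H]2C[C@@H]3OP(=O)(O)OC[C@H]3O2)c(=O)[nH]c1=O`, gives 60 ug/mL in this assay
- compound 3, `CCCCCCCCc1cn([C@H]2C[C@@H]3OP(=O)(O)OC[C@H]3O2)c(=O)[nH]c1=O`, gives 165 ug/mL in this assay

Compound 3 has the highest number of the three, so it is the weakest inhibitor shown; compound 2 is the nearest to it and compound 1 the furthest, both with lower numbers beyond the scatter. Compound 4, `CCCCCCc1cn([C@H]2C[C@@H]3OP(=O)(O)OC[C@H]3O2)c(=O)[nH]c1=O`, is not yet measured. It differs from compound 3 in one place: hydrogen in place of ethyl on a saturated chain carbon, six bonds along the chain from an aromatic carbon. Compound 4 therefore sits between compound 2 and compound 3 in chain length.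

Within the data shown here, only one measured step bears on this change, a 2.8-fold higher number from compound 2 to compound 3 (0.44 log units; beyond the scatter), where a longer chain went with a higher number. Taking part of that chain away again is expected to move the number the other way, by a step smaller than that one. The estimate for compound 4 is 100 ug/mL, with a range of 50 ug/mL to 220 ug/mL, which means an expected step of a 1.7-fold lower number from compound 3 to compound 4 (0.22 log units; within the scatter) in this assay.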

Compound 4, concentration for 50% inhibition: > 500 ug/mL
Compound 4: no number, only a limit; the forecaster's own chance of this, stated with the estimate: 5%; middle value at least 5.0-fold (0.69 log units) away from the limit.
By their numbers in this assay, from the lowest: compounds 1 and 2 (each within the scatter of the next); then compound 3. At a limit, above all of these: compound 4.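

Compound 4 gives > 500 ug/mL in this assay, and this is a limit of the assay, not a number. Taking ethyl away gives an at least 3.0-fold higher number from compound 3 to compound 4 (0.48 log units; beyond the scatter), while adding butyl gives an at least 8.3-fold higher number from compound 2 to compound 4 (0.92 log units; beyond the scatter), so across compounds 2, 4 and 3 the number does not follow chain length in one direction: compound 4, with the middle chain, reads higher than both its shorter and its longer neighbour. Both steps are minimum sizes, and both rest on a single limit: the limit of > 500 ug/mL in this assay, at which 1 of the 4 values shown sits.

Going by these compounds, how far compound 4 lies past its limit remains unknown, so the true size of both steps stays open. Also open, on these data alone, is how a chain longer than that of compound 3, or an amine or a carboxylic acid on the chain, would read in this assay.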